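Pyridinyl for Hydroxyethylpyrazolyl on Two Related Cores

The source may hold more compounds than are shown below. What is called first, only, known or untested is meant among the compounds shown, and "the series" means these compounds.

Compound 1 `CC(c1cc2cccnc2cc1F)n1cnc2ncc(-c3cnn(CCO)c3)nc21` gives 175 nM in a functional assay on NCI-H1993 cells (Homo sapiens) for inhibition, read by CCK-8 assay, with a stated time of 72 h; a higher number here means a weaker inhibitor, a lower number a stronger inhibitor. Its partner compound 3 `CC(c1cc2cccnc2cc1F)n1cnc2ncc(-c3ccncc3)nc21` carries pyridin-4-yl in place of 1-(2-hydroxyethyl)-1H-pyrazol-4-yl on an aromatic carbon and gives 171 nM. This gives the step of a 1.0-fold lower number from compound 1 to compound 3 (0.01 log units; within the scatter), so the exchange left the read-out essentially unchanged on this core.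

Compound 2 `Cc1c(C(C)n2cnc3ncc(-c4cnn(CCO)c4)nc32)ccc2ncccc12` gives 726 nM. The difference between the core of compound 2 and the core of compound 1 is not broken down here. From compound 2 the same change leads to compound 4 `Cc1c(C(C)n2cnc3ncc(-c4ccncc4)nc32)ccc2ncccc12`, which carries pyridin-4-yl in place of 1-(2-hydroxyethyl)-1H-pyrazol-4-yl on an aromatic carbon and has not yet been measured.

Because the step of a 1.0-fold lower number from compound 1 to compound 3 (0.01 log units; within the scatter) lay within the scatter, compound 4 is expected to sit close to compound 2, with an expected step of a 1.0-fold lower number from compound 2 to compound 4 (0.02 log units; within the scatter). The estimate for compound 4 is 700 nM, expected to fall between 350 nM and 1400 nM.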

Compound 4, half-maximal inhibitory concentration: 950 nM
The estimate for compound 4 lay 1.4-fold (0.13 log units) below the measured number, and the stated range covers the measured number.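

In this assay, pyridin-4-yl in place of 1-(2-hydroxyethyl)-1H-pyrazol-4-yl gave a 1.3-fold higher number from compound 2 to compound 4 (0.12 log units; within the scatter), so on this core, too, the exchange moved the read-out no further than the scatter. The two cores agree on this exchange: the same change on two cores in this assay, a 1.0-fold lower number (0.01 log units; within the scatter) from compound 1 to compound 3 and a 1.3-fold higher number (0.12 log units; within the scatter) from compound 2 to compound 4, 1.3-fold (0.13 log units) apart, within the scatter of two such steps. This shows that the exchange carried over between these two cores, but it does not show that it would carry over to any other core, and it gives no reason for the match.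

The compounds shown leave open whether another group in this place, such as an aliphatic amine or a carboxylic acid, would move the read-out on either core. They also leave open which of the differences between the two cores matters for the read-out.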